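This account rests on a few compounds, and the source may have more. Where it says the series, first, only, none or still open, it means among the compounds named here.

Measured compounds:
- compound 1, `O=C1C=CC2(C=C1)OC(=O)C(c1cc3ccccc3s1)=C2c1ccccc1`: 5900 nM
- compound 2, `COc1c(Br)cc(C)cc1C1=C(c2ccccc2)C2(C=CC(=O)C=C2)OC1=O`: 5850 nM

Both compounds were tested in a functional assay on MCF7 cells (Homo sapiens) for antiproliferative activity, read by MTT assay, with a stated time of 48 h; a lower number here means a stronger inhibitor, a higher number a weaker inhibitor. In this assay compound 1 gives 5900 nM, and compound 2 gives 5850 nM. The two numbers lie within the usual scatter of each other, so on the evidence shown neither compound can be said to be stronger or weaker than the other; compound 1 stands level with the only other compound measured. The two differ in more than one place, so what the pair says about any single change is not separated out here.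

Compound 3, `N#Cc1ccc(C2=C(c3ccccc3)C3(C=CC(=O)C=C3)OC2=O)cc1`, has not yet been measured. It differs from compound 1 as follows: 4-cyanophenyl in place of 1-benzothiophen-2-yl on a double-bonded ring carbon. Within the data shown here, no measured pair shows what such a swap of one aromatic group for another does in this assay. Among the measured compounds shown here, the only guide is that compound 1 and compound 2, which carry different groups at this position, give values within the scatter of each other.

On that basis the step from compound 1 to compound 3 is expected to be small, a 1.0-fold higher number from compound 1 to compound 3 (0.01 log units; within the scatter), with no clear direction beyond the scatter. Compound 3 is therefore estimated at 6000 nM in this assay, with a likely range from 2500 nM to 15000 nM.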

Compound 3, half-maximal inhibitory concentration: 19000 nM
The estimate for compound 3 lay 3.2-fold (0.50 log units) below the measured number; the measured number lies above the stated range.
By their numbers in this assay, from the lowest: compounds 2 and 1 (each within the scatter of the next); then compound 3.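

Putting 4-cyanophenyl in place of 1-benzothiophen-2-yl on this double-bonded ring carbon gives a 3.2-fold higher number from compound 1 to compound 3 (0.51 log units; beyond the scatter) in this assay, and this is the first change in a single place among these compounds. It shows that the group at this position can shift the number beyond the scatter, and that this swap makes the compound a weaker inhibitor of cell growth, so aromatic groups here are not interchangeable. The change replaces a fused system of two aromatic rings, one holding sulfur, with a single carbon ring carrying a nitrile, but no measurement here explains the loss of strength or shows which part of the swap matters.

A plain phenyl group on this carbon would help to separate the effect of losing the fused ring from that of adding the nitrile, yet the compounds shown leave that comparison open. They also leave open whether an amine or a carboxylic acid in place of the nitrile on the phenyl ring would give a number closer to that of compound 1 or to that of compound 3.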